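Cyclohexylmethyl urea replaced by a fused aromatic urea

This account rests on a few compounds, and the source may have more. Where it says the series, first, only, none or still open, it means among the compounds named here.

Going by the values given here, compound 1 `COc1cc(NC(C)CCCNC(=O)NCC2CCCCC2)c2ncccc2c1` is one of two compounds measured in a functional assay on MCF7 cells (Homo sapiens), read by MTT assay, with a stated time of 72 h (on this read-out higher numbers stand for weaker inhibition and lower numbers for stronger inhibition), in which compound 1 gives 61000 nM, the highest of the two numbers. Among the compounds with values here, the only neighbour is compound 2 `COc1cc(NC(C)CCCNC(=O)NCc2ccccc2)c2ncccc2c1`, which in this assay gives 25000 nM; the step of a 2.4-fold lower number from compound 1 to compound 2 (0.39 log units; beyond the scatter) is modest. Compound 3 `COc1cc(NC(C)CCCNC(=O)n2nnc3ccccc32)c2ncccc2c1` has not yet been measured. It differs from compound 1 on the carbonyl carbon whose other neighbour is an amide-type nitrogen: a group of 9 heavy atoms (6 carbon, 3 nitrogen; one five-membered aromatic ring with 3 hetero atoms, one six-membered aromatic ring of carbon only) in place of a group of 8 heavy atoms (7 carbon, 1 nitrogen; one six-membered non-aromatic ring of carbon only), on a carbonyl carbon. The step from compound 1 to compound 2 bears on this change only loosely, since there a phenyl replaced a cyclohexyl, whereas here the whole (cyclohexylmethyl)amino group leaves and an aromatic two-ring group with three nitrogens enters. A lower number is expected for compound 3, with wide uncertainty, because compound 2 with its aromatic ring gave 25000 nM. Compound 3 is therefore estimated at 30000 nM, between 8000 nM and 120000 nM, a step of a 2.0-fold lower number from compound 1 to compound 3 (0.31 log units; beyond the scatter).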

Compound 3, half-maximal inhibitory concentration: > 100000 nM
Compound 3 gave a limit, no number (the forecaster's own chance of this, stated with the estimate: 15%); middle value at least 3.3-fold (0.52 log units) from the limit.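

In this assay compound 3 gives > 100000 nM as a limit of the assay and not a number. On the carbonyl carbon, the group with the two aromatic rings gives an at least 1.6-fold higher number from compound 1 to compound 3 (0.21 log units; that floor lies within the scatter), a floor within the scatter, so no order can be read for that pair, whereas the comparison with the other urea gives an at least 4.0-fold higher number from compound 2 to compound 3 (0.60 log units; beyond the scatter), which lies beyond the scatter. The lower number that came with a phenyl ring in compound 2 therefore does not carry over to this aromatic two-ring group, which also has no hydrogen-bond donor, and the full size of both steps stays hidden: the limit of > 100000 nM in this assay, at which 1 of the 3 values shown sits.

As far as these compounds go, how far compound 3 lies beyond its limit remains open. Also open, from the compounds shown here alone, is what an anilino group or a morpholine on this carbonyl carbon would give.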